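Replacing the ring of compound 3 with carbamoylmethyl

The source may hold more compounds than are shown below. What is called first, only, known or untested is meant among the compounds shown, and "the series" means these compounds.

In an ADME assay on microsomes from liver (Mus musculus) for metabolic stability (on this read-out lower numbers stand for a shorter-lived compound and higher numbers for a longer-lived compound), compound 1 `CC(C)C(c1nnc[nH]1)c1ccc(-c2ccc3cccc(F)c3c2)[nH]c1=O` gives 0.213 h and compound 2 `CC(C)C(Cc1nnn[nH]1)c1ccc(-c2ccc3cccc(F)c3c2)[nH]c1=O` gives 0.853 h. Compound 3 `CC(C)C(c1noc(=O)[nH]1)c1ccc(-c2ccc3cccc(F)c3c2)[nH]c1=O` gives > 3 h, which is a limit of the assay and not a number. It therefore sits at the long-lived end of this short series. Compound 4 `CC(C)C(CC(N)=O)c1ccc(-c2ccc3cccc(F)c3c2)[nH]c1=O` differs from it by a group of 4 heavy atoms (2 carbon, 1 nitrogen, 1 oxygen; no ring) in place of a group of 6 heavy atoms (2 carbon, 2 nitrogen, 2 oxygen; one five-membered aromatic ring with 3 hetero atoms), on a saturated chain carbon bound to an aromatic carbon and a saturated chain carbon. Changing this group has mattered before: an at least 14-fold higher number from compound 1 to compound 3 (1.14 log units; beyond the scatter), and an at least 3.5-fold higher number from compound 2 to compound 3 (0.54 log units; beyond the scatter). Compound 2, whose (1H-tetrazol-5-yl)methyl group is the nearest match to carbamoylmethyl, offers the closest guide at 0.853 h. A shorter life is therefore expected, with an estimated step of an at least 3.3-fold lower number from compound 3 to compound 4 (0.52 log units; beyond the scatter). For compound 4 the estimated half-life is 0.9 h, with an expected range of 0.3 h to 2.7 h.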

Compound 4, half-life: < 0.0667 h
Compound 4: only a limit was reported; the forecaster's own chance of this, stated with the estimate: 10%; middle value at least 13-fold (1.13 log units) away from the limit.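

With carbamoylmethyl at this place, compound 4 is the shortest-lived of the series in this assay, with an at least 44-fold lower number from compound 3 to compound 4 (1.65 log units; beyond the scatter), an at least 12-fold lower number from compound 2 to compound 4 (1.10 log units; beyond the scatter) and an at least 3.1-fold lower number from compound 1 to compound 4 (0.50 log units; beyond the scatter). Compound 2 carries its ring on the same chain carbon that bears the carbamoyl in compound 4, so this comparison shows that the end group matters even when the chain stays the same. Compound 4 gives < 0.0667 h, which is a limit and not a number, so these steps are minimum sizes only: the limit of < 0.0667 h in this assay, at which 1 of the 4 values shown sits.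

Still open, going by these compounds, is whether a carboxylic acid or an amine in place of the carbamoyl would give a life as short as that of compound 4 or one closer to those of the ring-bearing compounds.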